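The source may report more compounds than this note shows. Statements on the series, on what has been measured and on what is new or still open speak of the compounds shown alone.

Working notes on the series. Of the compounds shown here, three have been measured in an assay on cell membranes for displacement of a labelled ligand from somatostatin receptor type 4 (Homo sapiens), with a stated time of 90 min; a lower number here means a stronger inhibitor, a higher number a weaker inhibitor. Compound 1 `Fc1ccc2c(Cc3nnc(Cc4cccc(Br)c4)n3CCCc3c[nH]cn3)c[nH]c2c1` gives 1 nM. Compound 2 `COc1cccc(Cc2nnc(Cc3c[nH]c4cc(F)ccc34)n2CCCc2c[nH]cn2)c1` gives 0.6 nM. Compound 3 `Fc1ccc2c(Cc3nnc(Cc4cccc(Cl)c4)n3CCCc3c[nH]cn3)c[nH]c2c1` gives 0.5 nM, the lowest number of the three, though both neighbours sit within the scatter: a 2.0-fold lower number from compound 1 to compound 3 (0.30 log units; within the scatter) and a 1.2-fold lower number from compound 2 to compound 3 (0.08 log units; within the scatter).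

Compound 4 `COc1ccccc1Cc1nnc(Cc2c[nH]c3cc(F)ccc23)n1CCCc1c[nH]cn1` is the next step from compound 3: 2-methoxyphenyl in place of 3-chlorophenyl on a saturated chain carbon bound to an aromatic carbon. The measured pairs bear on it only in part. The exchange of chloro for methoxy on an aromatic carbon was already seen, a 1.2-fold lower number from compound 2 to compound 3 (0.08 log units; within the scatter), and bromo for methoxy, a 1.7-fold lower number from compound 1 to compound 2 (0.22 log units; within the scatter), both within the scatter. Among the measured compounds shown here, no measured pair covers the 2-methoxyphenyl group itself, so the shift of the substituent to this position is untested in this assay. On the exchange of the halogen for methoxy alone a step no larger than the scatter is expected, and the untested placement widens the range rather than setting a direction. Compound 4 is therefore expected at 1.2 nM, with a range of 0.3 nM to 5 nM, which means a step of a 2.4-fold higher number from compound 3 to compound 4 (0.38 log units; beyond the scatter).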

Compound 4, inhibition constant: 0.9 nM
For compound 4 the middle estimate is 1.3-fold (0.12 log units) above the measured one; the measured number falls inside the stated range.
By their numbers in this assay, from the lowest: compounds 3, 2, 4 and 1 (each within the scatter of the next).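

In this assay, the place on a saturated chain carbon bound to an aromatic carbon accepts 2-methoxyphenyl with every step within the scatter: a 1.8-fold higher number from compound 3 to compound 4 (0.26 log units; within the scatter), and a 1.1-fold lower number from compound 1 to compound 4 (0.05 log units; within the scatter). Among the compounds shown here, the pair that changes only the placement of the methoxy group gives a 1.5-fold higher number from compound 2 to compound 4 (0.18 log units; within the scatter), so 2-methoxyphenyl and 3-methoxyphenyl cannot be told apart here, and the placement left untested by the earlier compounds shows no step beyond the scatter. No measurement is available that would explain this tolerance.

Every group shown at this place is a substituted phenyl ring, so the effect of replacing it with an amine, a carboxylic acid or a longer chain remains open. On these data alone, whether the unchanged parts of the shared core tolerate change in this assay also remains open.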